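From Pyridinyl to a Dioxolanylmethyl Group on the Ring Nitrogen

A few compounds are considered here, and "the series" means these few. Any claim that something is new, unique, unknown or untested is made for them only; others in the source may bear on it.

Measured compounds:
compound 1, `c1ccc(-n2cc(CSc3nc4ccccc4s3)nn2)cc1`: 46.7%
compound 2, `c1cncc(-n2cc(CSc3nc4ccccc4s3)nn2)c1`: 64%

In a functional assay on the whole organism (strain Albino Wistar) for inhibition, with Rattus norvegicus as the target, read by paw edema, with stated times of 1 h and 3 h, at a dose of 10 mg/kg by the oral route (on this read-out higher numbers stand for more inhibition at the one dose given (going by the name of the read-out) and lower numbers for less inhibition), compound 2 gives 64%, the highest of the two numbers. Compound 1 gives 46.7%, so the step is a number 17.3 percentage points higher from compound 1 to compound 2 (beyond the scatter). Compound 3, `CC1(C)OCC(Cn2cc(CSc3nc4ccccc4s3)nn2)O1`, departs from compound 2 in one place: (2,2-dimethyl-1,3-dioxolan-4-yl)methyl in place of pyridin-3-yl on an aromatic nitrogen.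

Among the measured compounds shown here, the single measured step exchanged one six-membered aromatic ring for another on the same aromatic nitrogen. For the measured compounds named here, no measured step exchanges an aromatic ring for a non-aromatic ring carrying a methylene, so that step bears on compound 3 only loosely. The record gives no guide to the direction, and a move back toward the region of compound 1 is as plausible as staying near compound 2. The step from compound 2 to compound 3 is therefore expected to be a number 14 percentage points lower from compound 2 to compound 3 (beyond the scatter) in this assay, with wide uncertainty. Compound 3 is estimated to give 50% in this assay, within a range from 30% to 70%.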

Compound 3, a percentage reported as inhibition, in the whole organism at one dose (the size of the read-out at that dose, not a potency): 53.3%
Compound 3: middle estimate off by 3.3 percentage points, on the low side; the measured number falls inside the stated range.
By their numbers in this assay, from the lowest: compounds 1 and 3 (each within the scatter of the next); then compound 2.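

In this assay, the (2,2-dimethyl-1,3-dioxolan-4-yl)methyl group shows that this ring nitrogen can carry a non-aromatic ring and still give a clear reading, although the exchange for pyridin-3-yl gives a number 10.7 percentage points lower from compound 2 to compound 3 (beyond the scatter). Set against phenyl, the same group gives a number 6.6 percentage points higher from compound 1 to compound 3 (within the scatter), so compound 3 cannot be told apart from compound 1, and among these three compounds only compound 2 stands clear of the others. No measurement offered here accounts for the difference between these groups.

The compounds shown leave open whether the dioxolane ring itself matters or whether an open chain such as 2,3-dihydroxypropyl or aminoethyl on the same nitrogen would read alike. They also leave open how pyridin-2-yl or pyridin-4-yl would compare with pyridin-3-yl.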